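The compounds below may be only part of what the source reports. "The series", "measured", "known", "first", "only" and "open" are said of these compounds alone.

Measured compounds:
compound 1 `CCOC(=O)C1=C(Nc2cccc(F)c2)S/C(=C\c2ccc[nH]2)C1=O` – < 10%
compound 2 `CCOC(=O)C1=C(Nc2cccc(C(F)(F)F)c2)S/C(=C\c2ccc[nH]2)C1=O` – 22.9%

In a functional assay on MCF7 cells (Homo sapiens) for inhibition, read by MTT assay, with a stated time of 72 h, tested at 10 uM (a higher number here means more inhibition at the concentration tested (going by the name of the read-out), a lower number less inhibition), compound 1 gives < 10%, which is a limit of the assay and not a number. Compound 2 gives 22.9% in this assay. Going by the values given here, the one measured step is a number at least 12.9 percentage points higher from compound 1 to compound 2 (beyond the scatter), a change of trifluoromethyl in place of fluoro on an aromatic carbon. Among the compounds with values here, compound 2 thus holds the only number in this assay; the other value shown sits at a limit, (the limit of < 10% in this assay, at which 1 of the 2 values shown sits).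

Compound 3 is `CCOC(=O)C1=C(Nc2cccc([N+](=O)[O-])c2)S/C(=C\c2ccc[nH]2)C1=O`. It differs from compound 2 by nitro in place of trifluoromethyl on an aromatic carbon. Within the data shown here, no measured step involves a nitro group, so the exchange of nitro for trifluoromethyl has no direct precedent here; the only reference is a number at least 12.9 percentage points higher from compound 1 to compound 2 (beyond the scatter), which concerns a different pair of groups. With nothing pointing either way, no step beyond the scatter is expected for compound 3 in this assay, and the estimate for compound 3 is 22%, with a range from 8% to 40%. The expected step is a number 0.9 percentage points lower from compound 2 to compound 3 (within the scatter), with a real chance that compound 3 returns only a limit.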

Compound 3, a percentage reported as inhibition, at one concentration (the size of the read-out at that concentration, not a potency): 27.4%
For compound 3 the middle estimate is 5.4 percentage points below the measured one, within the range that was stated.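

In this assay, a second group at the aromatic carbon meta to a large group can now be set against trifluoromethyl: nitro in place of trifluoromethyl gives a number 4.5 percentage points higher from compound 2 to compound 3 (within the scatter), so the two groups cannot be told apart here, although they differ in heavy atoms and in counted hydrogen-bond acceptors. Nitro in place of fluoro gives a number at least 17.4 percentage points higher from compound 1 to compound 3 (beyond the scatter), so the separation from fluoro no longer rests on trifluoromethyl alone, and fluoro is the one group shown that stands apart from the other two. The size of both separations from fluoro remains a lower bound, as the fluoro compound supplies a limit and not a number: the limit of < 10% in this assay, at which 1 of the 3 values shown sits.

Still open, as far as these compounds go, is whether a group of another kind at this position, such as an amine or a carboxylic acid, would stay level with nitro and trifluoromethyl or fall back toward fluoro. The rest of the shared core is unchanged across the compounds shown, and the read-out comes from one concentration, so neither the effect of changes elsewhere nor the potency of any compound can be read.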